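This account rests on a few compounds, and the source may have more. Where it says the series, first, only, none or still open, it means among the compounds named here.

Measured so far in a functional assay on PC-3 cells (Homo sapiens) for inhibition, read by MTT assay, with a stated time of 48 h, tested at 10 uM; a lower number here means less inhibition of growth, a higher number more inhibition of growth at the concentration tested:
- Compound 1 `Cc1cc(=O)c2c(O)c(CN3CCCC3C(=O)O)c(O)c([C@H]3CCN(C)C[C@H]3O)c2o1`: 0%
- Compound 2 `Cc1oc2c([C@H]3CCN(C)C[C@H]3O)c(O)cc(O)c2c(=O)c1C(O)c1ccc(F)c(Br)c1`: 72%

Of these two numbers, compound 2 has the higher at 72%, and the gap down to compound 1 lies beyond the usual scatter. These two compounds differ in more than one place, so their gap cannot be pinned on any single group.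

Compound 3 `CCOc1ccc(Br)c(C(O)c2c(C)oc3c([C@H]4CCN(C)C[C@H]4O)c(O)cc(O)c3c2=O)c1` keeps the core of compound 2 and changes one group: 2-bromo-5-ethoxyphenyl in place of 3-bromo-4-fluorophenyl on a saturated chain carbon bound to an aromatic carbon and an oxygen on a saturated carbon. For the measured compounds named here, no measured pair shows what such a swap does in this assay, so the direction is an uncertain judgement. A moderate fall is expected, with an estimated a number 14 percentage points lower from compound 2 to compound 3 (beyond the scatter). The estimate for compound 3 is 58%, with an expected range from 28% to 85%.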

Compound 3, percent growth inhibition at one concentration: 0%
Compound 3: the middle estimate sits 58 percentage points above what was measured; the whole stated range lies above it.
By their numbers in this assay, from the lowest: compounds 1 and 3 (each within the scatter of the next); then compound 2.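

In this assay, the change of 3-bromo-4-fluorophenyl to 2-bromo-5-ethoxyphenyl on this saturated chain carbon gives a number 72 percentage points lower from compound 2 to compound 3 (beyond the scatter), the first measured sign that the aryl group here can decide the result. Both groups carry a bromine on a single six-membered aromatic ring, so a bromine-bearing ring at this place does not by itself secure growth inhibition. Nothing available explains the loss.

The step changes the fluorine to an ethoxy group and also alters the substitution pattern, so the compounds shown cannot say which of these matters. A 3-bromo-4-ethoxyphenyl group at this place would keep the original pattern with the ethoxy group, while a plain phenyl group would show what the ring does without bromine, fluorine or ethoxy.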